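This account rests on a few compounds, and the source may have more. Where it says the series, first, only, none or still open, it means among the compounds named here.

Measured so far:
compound 1 `CC(C)=CCn1c(CN2CCN(C(=O)C3CC3)CC2)nc2ccccc21` with 74.3%
compound 2 `Cc1cccc(Cn2c(CN3CCN(C(=O)c4cccnc4)CC3)nc3ccccc32)c1` with 24.5%
compound 3 `O=C(C1CC1)N1CCN(Cc2nc3ccccc3n2Cc2ccc(Cl)cc2)CC1` with 56.6%

In an assay on isolated protein for inhibition of aldehyde dehydrogenase 1A1 (Homo sapiens), read by spectrophotometry, tested at 10 uM (a lower number here means less inhibition, a higher number more inhibition at the concentration tested (going by the name of the read-out)), compound 2 stands lowest of the three; compound 3 lies next to it, and compound 1 lies furthest from it, each beyond the scatter. Compound 4 `CCCC(=O)N1CCN(Cc2nc3ccccc3n2Cc2cccc(C)c2)CC1` has not yet been measured. Its change from compound 2 is propyl in place of pyridin-3-yl on a carbonyl carbon, so that the (pyridin-3-yl)carbonyl of compound 2 becomes a propylcarbonyl.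

Among the compounds with values here, only one step among the measured compounds is a single change, a number 17.7 percentage points lower from compound 1 to compound 3 (beyond the scatter), and it concerns the group on the saturated chain carbon bound to the aromatic nitrogen, not the carbonyl carbon. Within the data shown here, no measured step therefore bears directly on the change in hand. What can be said is that compound 1 and compound 3, which both carry a small saturated ring on the carbonyl carbon, give higher inhibition than compound 2, yet they also differ from compound 2 elsewhere, so this is a hint and not a measured step. A rise of moderate size is expected, but with wide uncertainty: the step from compound 2 to compound 4 is estimated as a number 20.5 percentage points higher from compound 2 to compound 4 (beyond the scatter). For compound 4 the inhibition is estimated at 45%, within a range from 20% to 70%.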

Compound 4, a percentage reported as inhibition, at one concentration (the size of the read-out at that concentration, not a potency): 79.1%
Beside the measured number, compound 4's estimate is 34.1 percentage points below it; the measured number lies above the stated range.
By their numbers in this assay, from the lowest: compound 2; then compound 3; then compounds 1 and 4 (each within the scatter of the next).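

Within the data shown here, this is the first measured single change at the carbonyl carbon whose other neighbour is the amide-type nitrogen in a ring. In this assay, among these compounds, putting propyl in place of pyridin-3-yl gives a number 54.6 percentage points higher from compound 2 to compound 4 (beyond the scatter) and counts as a large step, so the group at this one place can by itself shift the inhibition strongly, whereas the only earlier single change, at a different place, gave a modest a number 17.7 percentage points lower from compound 1 to compound 3 (beyond the scatter) in the same read-out. The change removes a six-membered aromatic ring with one hetero atom and brings in an open chain, but no measurement here explains why the inhibition rises so much.

The step cannot separate the loss of the ring nitrogen from the loss of the aromatic ring itself, and a phenyl group on the same carbonyl carbon, with its ring but no ring nitrogen, would begin to tell those two apart. On these data alone, how far the open chain can go also stays unknown, since a longer chain such as pentyl, or a chain ending in an amine, could hold, raise or lower the inhibition at this place.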